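Ethyl to methyl on the core of compound 1

The source may report more compounds than this note shows. Statements on the series, on what has been measured and on what is new or still open speak of the compounds shown alone.

Compound 1 `CCn1c(=O)[nH]c2c(cnn2-c2cccc(Cl)c2)c1=N` stands highest of the three measured compounds: in an assay on membranes from brain for binding affinity to adenosine receptor A1 (Rattus norvegicus), read by radioligand binding, tested at 20 uM (on this read-out lower numbers stand for less inhibition and higher numbers for more inhibition at the one concentration tested (going by the name of the read-out)), compound 1 gives 70%. Within the data shown here, compound 2 `Cn1c(=O)[nH]c2c(cnn2-c2ccc(Cl)cc2)c1=N` gives 37%, and compound 3 `Cn1c(=O)[nH]c2c(cnn2-c2ccc(N)cc2)c1=N` gives 0%; the only single-change step, a number 37 percentage points lower from compound 2 to compound 3 (beyond the scatter), is large. Compound 4 `Cn1c(=O)[nH]c2c(cnn2-c2cccc(Cl)c2)c1=N` differs from compound 1 by hydrogen in place of methyl on a saturated chain carbon bound to an aromatic nitrogen, which read one bond further out is ethyl to methyl. Among the measured compounds shown here, no measured step bears on this change; compound 1 and compound 2 differ in two places at once, so their gap cannot be apportioned. The expected step of a number 10 percentage points lower from compound 1 to compound 4 (within the scatter) is therefore set at no more than the scatter, with a wide allowance either way. The estimate for compound 4 is 60%, expected within 35% to 80%.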

Compound 4, a percentage reported as inhibition, at one concentration (the size of the read-out at that concentration, not a potency): 53%
Beside the measured number, compound 4's estimate is 7 percentage points above it; low and high end bracket the measured number.
By their numbers in this assay, from the lowest: compound 3; then compound 2; then compound 4; then compound 1.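

Going from ethyl to methyl at this position gives a number 17 percentage points lower from compound 1 to compound 4 (beyond the scatter) in this assay and so shows that the chain on the aromatic nitrogen has a measurable bearing on the read-out, which the earlier chloro to amino step could not show. With the methyl chain, compound 4 still gives 53% and so keeps much of the inhibition seen with ethyl. Nothing measured here explains the step.

From the compounds shown here alone, whether a longer chain such as propyl would raise or lower the number remains open. So does the effect of an amine or a carboxylic acid at the end of that chain.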